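The compounds below may be only part of what the source reports. "The series", "measured", "known", "first", "only" and "open" are said of these compounds alone.

Measured so far in a functional assay for antagonist activity at transient receptor potential cation channel subfamily V member 1 (Homo sapiens), read by FLIPR; on this read-out lower numbers stand for stronger inhibition and higher numbers for weaker inhibition:
- compound 1, `CC(C)(C)c1ccc(NC(=O)c2ccc(-c3ncccc3C(=O)O)cc2)cc1`: > 4000 nM
- compound 2, `CN(C)Cc1cccnc1-c1ccc(C(=O)Nc2ccc(C(C)(C)C)cc2)cc1`: 746 nM

Compound 1 sits at a limit of this assay, (the limit of > 4000 nM in this assay, at which 1 of the 2 values shown sits), and its value is therefore not a number. Going by the values given here, compound 2 is the only compound of the pair with a number, so it is the sole anchor for the series in this assay. Among the compounds with values here, the one measured step, carboxy replaced by (dimethylamino)methyl on an aromatic carbon, gave an at least 5.3-fold lower number from compound 1 to compound 2 (0.72 log units; beyond the scatter); its size is open at one end, since compound 1 stands at a limit.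

Compound 3, `Cc1nnc(-c2cccnc2-c2ccc(C(=O)Nc3ccc(C(C)(C)C)cc3)cc2)o1`, has not been measured. It differs from compound 2 in 5-methyl-1,3,4-oxadiazol-2-yl in place of (dimethylamino)methyl on an aromatic carbon. Within the data shown here, no measured step resembles this exchange: the step from compound 1 to compound 2 swapped an acid for a basic amine, whereas here the basic amine gives way to a neutral heteroaromatic ring. The measured step therefore says little about direction, and a change within or just beyond the scatter in this assay is expected. Compound 3 is estimated at 1000 nM, between 250 nM and 4000 nM, which means an expected step of a 1.3-fold higher number from compound 2 to compound 3 (0.13 log units; within the scatter).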

Compound 3, half-maximal inhibitory concentration: 387 nM
For compound 3 the middle estimate is 2.6-fold (0.41 log units) above the measured one, within the range that was stated.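

In this assay, replacing (dimethylamino)methyl on this aromatic carbon, ortho to a large group, with 5-methyl-1,3,4-oxadiazol-2-yl gave a 1.9-fold lower number from compound 2 to compound 3 (0.29 log units; within the scatter), so the two groups cannot be told apart here and a dimethylamino group is not needed for a value in this range. Set against carboxy at the same carbon, the five-membered aromatic ring gave an at least 10-fold lower number from compound 1 to compound 3 (1.01 log units; beyond the scatter), which makes it the second group in the series with a step from carboxy beyond the scatter, after (dimethylamino)methyl. Compound 1 stands at a limit and has no number, so the size of both steps from it stays open at one end: the limit of > 4000 nM in this assay, at which 1 of the 3 values shown sits.

Going by these compounds, it remains open whether the methyl on the five-membered ring contributes at all, and how a primary amide, a nitrile or a morpholinomethyl group would read at this carbon. On these data alone, the rest of the core is the same in all three compounds, so whether the equivalence of compound 2 and compound 3 would hold with a different group in place of the tert-butyl also remains open.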